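This account rests on a few compounds, and the source may have more. Where it says the series, first, only, none or still open, it means among the compounds named here.

Measured compounds:
- compound 1, `CC(=O)OCC(CCn1cc(C#Cc2ccc(Br)cc2)c(=O)n(C(=O)c2ccccc2)c1=O)COC(C)=O`: 28900 nM
- compound 2, `CC(=O)OCC(CCn1cc(C#CCc2ccccc2)c(=O)n(C(=O)c2ccccc2)c1=O)COC(C)=O`: 26800 nM
- compound 3, `O=c1[nH]c(=O)n(CCC(CO)CO)cc1C#Cc1ccc(Br)cc1`: 46000 nM

All three were tested in a functional assay on MCF7 cells (Homo sapiens) for antiproliferative activity, read by MTT assay, with a stated time of 72 h; a higher number here means a weaker inhibitor, a lower number a stronger inhibitor. Compound 1 gives 28900 nM in this assay, and compound 2 gives 26800 nM. The change between them is benzyl in place of 4-bromophenyl on a triple-bonded carbon, and the step it made was a 1.1-fold lower number from compound 1 to compound 2 (0.03 log units; within the scatter). Compound 3, which carries a different core, gives 46000 nM in this assay; the difference between its core and that of compound 1 is not broken down here, and its values beside those of compound 1 and compound 2 all lie within the usual scatter of each other.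

Compound 4, `O=c1[nH]c(=O)n(CCC(CO)CO)cc1C#CCc1ccccc1`, has not yet been measured. It differs from compound 3 by benzyl in place of 4-bromophenyl on a triple-bonded carbon, the same change that was made from compound 1 to compound 2, at the same kind of place. Because that earlier change gave a 1.1-fold lower number from compound 1 to compound 2 (0.03 log units; within the scatter), the step from compound 3 to compound 4 in this assay is expected to be small, about a 1.1-fold lower number from compound 3 to compound 4 (0.03 log units; within the scatter). Compound 4 is therefore estimated at 43000 nM, with a likely range from 20000 nM to 90000 nM.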

Compound 4, half-maximal inhibitory concentration: > 100000 nM
Compound 4 gave a limit, no number (the forecaster's own chance of this, stated with the estimate: 20%); at least 2.3-fold (0.36 log units) between middle value and limit.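

In this assay compound 4 gives > 100000 nM, which is a limit of the assay and not a number. Replacing 4-bromophenyl with benzyl on the triple-bonded carbon gave an at least 2.1-fold higher number from compound 3 to compound 4 (0.33 log units; beyond the scatter), so on this core the change does cost activity, by an amount beyond the usual scatter. What this does not show is whether the change truly behaves differently on the two cores, and so whether it can be carried from one to the other with the same result: the same change on two cores in this assay, a 1.1-fold lower number (0.03 log units; within the scatter) from compound 1 to compound 2 and an at least 2.1-fold higher number (0.33 log units; beyond the scatter) from compound 3 to compound 4; the limit leaves it open whether they differ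

From the compounds shown here alone, the real size of the step on the core of compound 3 stays unknown, as the limit gives only its lower bound. Going by these compounds, whether a phenyl group without bromine, or a longer chain in place of benzyl, would give steps that match on both cores also remains open.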